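Hydroxy in Place of Chloro on the Triazole Aryl

The source may report more compounds than this note shows. Statements on the series, on what has been measured and on what is new or still open speak of the compounds shown alone.

Three compounds on a shared core were tested in a functional assay on DU-145 cells (Homo sapiens) for antiproliferative activity, read by MTT assay, with a stated time of 48 h; a lower number here means a stronger inhibitor, a higher number a weaker inhibitor. Compound 3 `C/C(=C\CC/C(C)=C/CC[C@@H]1[C@@]2(C)CCC(=O)C(C)(C)[C@H]2CC[C@@]1(C)O)CC/C=C(\C)C(=O)OCc1cn(-c2cccc(Cl)c2)nn1` gives 103000 nM, the lowest of the two numbers shown. Its nearest neighbour, compound 2 `C/C(=C\CC/C(C)=C/CC[C@@H]1[C@@]2(C)CCC(=O)C(C)(C)[C@H]2CC[C@@]1(C)O)CC/C=C(\C)C(=O)OCc1cn(-c2cccc(C)c2)nn1`, gives 137000 nM, and a 1.3-fold lower number from compound 2 to compound 3 (0.12 log units; within the scatter). Compound 1 `C/C(=C\CC/C(C)=C/CC[C@@H]1[C@@]2(C)CCC(=O)C(C)(C)[C@H]2CC[C@@]1(C)O)CC/C=C(\C)C(=O)OCc1cn(-c2ccc(F)cc2)nn1` is recorded at > 150000 nM, which is a limit of the assay and not a number. Against that limit, an at least 1.0-fold lower number from compound 1 to compound 2 (0.03 log units; that floor lies within the scatter) and an at least 1.4-fold lower number from compound 1 to compound 3 (0.16 log units; that floor lies within the scatter). Compound 4 `C/C(=C\CC/C(C)=C/CC[C@@H]1[C@@]2(C)CCC(=O)C(C)(C)[C@H]2CC[C@@]1(C)O)CC/C=C(\C)C(=O)OCc1cn(-c2cccc(O)c2)nn1` carries hydroxy in place of chloro on an aromatic carbon. Among the measured compounds shown here, no measured step exchanges chloro for hydroxy, and every step among the aryl substituents stays within the scatter, so no movement beyond the scatter is expected here. Compound 4 is therefore estimated at 120000 nM, between 50000 nM and 300000 nM. The expected step is a 1.2-fold higher number from compound 3 to compound 4 (0.07 log units; within the scatter).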

Compound 4, half-maximal inhibitory concentration: 28400 nM
For compound 4 the middle estimate is 4.2-fold (0.63 log units) above the measured one; measured number below the stated range.
By their numbers in this assay, from the lowest: compound 4; then compounds 3 and 2 (each within the scatter of the next). At a limit, above all of these: compound 1.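

Among the aryl substituents shown, on an aromatic carbon meta to a large group, only hydroxy moves the number beyond the scatter, with a 3.6-fold lower number from compound 3 to compound 4 (0.56 log units; beyond the scatter) and a 4.8-fold lower number from compound 2 to compound 4 (0.68 log units; beyond the scatter), while chloro and methyl stay within the scatter of each other. The comparison with the 4-fluorophenyl compound gives only a floor, an at least 5.2-fold lower number from compound 1 to compound 4 (0.72 log units; beyond the scatter). Compound 1 is recorded at a limit and not a number: the limit of > 150000 nM in this assay, at which 1 of the 4 values shown sits.

The compounds shown leave open whether an amine or a methoxy group in the same place would give a step of this size. They also leave open whether hydroxy would do so elsewhere on the aryl ring.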